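The source may report more compounds than this note shows. Statements on the series, on what has been measured and on what is new or still open speak of the compounds shown alone.

In a functional assay on HepG2 cells (Homo sapiens) for inhibition, read by MTT assay, with a stated time of 72 h (on this read-out higher numbers stand for weaker inhibition and lower numbers for stronger inhibition), compound 2 `CC(C)(C)n1cc2c(n1)C(=O)CC1(CCN(C(=O)c3cc(-c4ccccc4Cl)nc4ccccc34)CC1)O2` gives > 10000 nM as a limit of the assay, not a number. Compound 1 `Cc1ccccc1-c1cc(C(=O)N2CCC3(CC2)CC(=O)c2nn(C(C)(C)C)cc2O3)c2ccccc2n1` also gives a limit, > 10000 nM in this case. Compound 3 `COc1ccc(-c2cc(C(=O)N3CCC4(CC3)CC(=O)c3nn(C(C)(C)C)cc3O4)c3ccccc3n2)cc1OC` gives a real number, 1560 nM on the same read-out. Compound 2 therefore stands at the limit of > 10000 nM in this assay, at which 2 of the 3 values shown sit, with no exact value of its own.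

Compound 4 `CC(C)(C)n1cc2c(n1)C(=O)CC1(CCN(C(=O)c3cc(-c4ccncc4)nc4ccccc34)CC1)O2` has not yet been measured. The change is pyridin-4-yl in place of 2-chlorophenyl on an aromatic carbon and puts pyridin-4-yl in place of 2-chlorophenyl on an aromatic carbon, next to the ring nitrogen. Two measured steps alter the group at that same carbon, both by bringing in 3,4-dimethoxyphenyl: an at least 6.4-fold lower number from compound 2 to compound 3 (0.80 log units; beyond the scatter) and an at least 6.4-fold lower number from compound 1 to compound 3 (0.80 log units; beyond the scatter) are the guides here. The remaining one is a step that the two limits leave unreadable from compound 1 to compound 2 and gives no guidance. Pyridin-4-yl is a different group and both useful steps end at compound 3, so only a modest move toward lower numbers is expected, and another limit remains possible. That expectation amounts to an at least 1.6-fold lower number from compound 2 to compound 4 (0.22 log units; that floor lies within the scatter) as the estimated step. For compound 4 the estimated value is 6000 nM with an expected range from 2000 nM to 18000 nM in this assay.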

Compound 4, half-maximal inhibitory concentration: 380 nM
Compound 4: the middle estimate sits 16-fold (1.20 log units) above what was measured; measured number below the stated range.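

In this assay, within the data shown here, the carbon next to the ring nitrogen proves far more responsive than the earlier compounds showed: pyridin-4-yl gives an at least 26-fold lower number from compound 2 to compound 4 (1.42 log units; beyond the scatter) and an at least 26-fold lower number from compound 1 to compound 4 (1.42 log units; beyond the scatter). Among these compounds, it also goes beyond the only earlier measured number, with a 4.1-fold lower number from compound 3 to compound 4 (0.61 log units; beyond the scatter), so 3,4-dimethoxyphenyl is not the only group here that brings a compound off the limit. Compound 2 gives only a limit, so the step that starts from it is a floor and its full size stays unknown: the limit of > 10000 nM in this assay, at which 2 of the 4 values shown sit.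

Because pyridin-4-yl differs from 2-chlorophenyl both by losing the chlorine and by gaining a ring nitrogen, the compounds shown cannot separate those two changes; plain phenyl would help to do so. Pyridin-3-yl would show whether the place of the ring nitrogen matters, and an amine on the ring remains untested here.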